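This account rests on a few compounds, and the source may have more. Where it says the series, first, only, none or still open, it means among the compounds named here.

Compound 1 `CNC(=O)CN1CCC(c2cc3c(-c4ccc(=O)n(C(C)C)c4)ccnc3[nH]2)CC1` gives 8.6 uL/min in an ADME assay on microsomes from liver (Homo sapiens) for metabolic stability; a lower number here means slower removal, a higher number faster removal of the compound.
Compound 2 `CC(C)n1nc(-c2ccnc3[nH]c(C4CCN(CC(=O)N(C)C)CC4)cc23)ccc1=O` gives 13 uL/min in this assay.
Compound 3 `CC(C)n1cc(-c2ccnc3[nH]c(C4CCN(CC(=O)N5CCCCC5)CC4)cc23)ccc1=O` reaches only the limit of this assay, > 300 uL/min.

Among these values, compound 2 and compound 1 sit within the scatter of each other, while the third value is a limit rather than a number (the limit of > 300 uL/min in this assay, at which 1 of the 3 values shown sits). Compound 4 `CCn1cc(-c2ccnc3[nH]c(C4CCN(CC(=O)N(C)C)CC4)cc23)ccc1=O` differs from compound 2 by a group of 9 heavy atoms (7 carbon, 1 nitrogen, 1 oxygen; one six-membered aromatic ring with 1 hetero atom) in place of a group of 10 heavy atoms (7 carbon, 2 nitrogen, 1 oxygen; one six-membered aromatic ring with 2 hetero atoms), on an aromatic carbon. Within the data shown here, the single measured step, an at least 34-fold higher number from compound 1 to compound 3 (1.54 log units; beyond the scatter), concerns a change at the carbonyl rather than at this aromatic carbon, so it gives no guide for the present change. A small step is therefore expected, a 1.2-fold higher number from compound 2 to compound 4 (0.06 log units; within the scatter), not clearly beyond the scatter. For compound 4 the estimate in this assay is 15 uL/min, between 6 uL/min and 40 uL/min.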

Compound 4, intrinsic clearance in a liver preparation (reported as CLH), per the amount of preparation that the assay uses: < 3 uL/min
Compound 4 ended at the assay's limit (the forecaster's own chance of this, stated with the estimate: 5%); middle value at least 5.0-fold (0.69 log units) away from the limit.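

Among these compounds, the aromatic group on the core also counts in this assay, not only the amide end of the molecule: changing it on this aromatic carbon gives an at least 4.3-fold lower number from compound 2 to compound 4 (0.63 log units; beyond the scatter), a step the earlier compounds did not show. The entering group differs from the leaving group in both ring hetero atoms and heavy atoms, so the step belongs to the whole group and not to either difference alone. Compound 4 stands at a limit of the assay, not at a number: the limit of < 3 uL/min in this assay, at which 1 of the 4 values shown sits.

On these data alone, the true size of the step therefore stays open. So does whether a cyclopropyl group in place of the ethyl would give a similar result.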